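Moving the trifluoromethyl group: compound 2 to compound 3

The source may report more compounds than this note shows. Statements on the series, on what has been measured and on what is new or still open speak of the compounds shown alone.

Compound 1 `CC(O)(CSc1ccc(F)cc1)C(=O)Nc1ccc(S(F)(F)(F)(F)F)cc1`: 12500 nM
Compound 2 `CC(O)(CSc1ccc(C(F)(F)F)cc1)C(=O)Nc1ccc(S(F)(F)(F)(F)F)cc1`: 17000 nM
Compound 3 `CC(O)(CSc1cccc(C(F)(F)F)c1)C(=O)Nc1ccc(S(F)(F)(F)(F)F)cc1`: not yet measured

Among the measured compounds shown here, in a functional assay on LNCaP cells (Homo sapiens) for antiproliferative activity, read by propidium iodide staining, with a stated time of 96 h (on this read-out lower numbers stand for stronger inhibition and higher numbers for weaker inhibition), compound 2 gives 17000 nM, which lies within the scatter of compound 1, the only other measured compound. Compound 3 carries 3-(trifluoromethyl)phenyl in place of 4-(trifluoromethyl)phenyl on a sulfur. For the measured compounds named here, the one measured step that bears on this change is a 1.4-fold higher number from compound 1 to compound 2 (0.13 log units; within the scatter), where trifluoromethyl replaced fluoro on an aromatic carbon. Going by the values given here, that step exchanged one group for another rather than moving a group, so it offers only indirect evidence, and no measured pair tests such a move. No step beyond the scatter, in either direction, is therefore expected in this assay. The expected step is a 1.1-fold lower number from compound 2 to compound 3 (0.03 log units; within the scatter). Compound 3 is estimated at 16000 nM, with an expected range of 7500 nM to 32000 nM.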

Compound 3, half-maximal inhibitory concentration: 18300 nM
For compound 3 the middle estimate is 1.1-fold (0.06 log units) below the measured one; measured number inside the range.
By their numbers in this assay, from the lowest: compounds 1, 2 and 3 (each within the scatter of the next).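

Among the compounds shown here, this is the first measured shift of the trifluoromethyl group on the phenyl held by the sulfur: in this assay, 3-(trifluoromethyl)phenyl in place of 4-(trifluoromethyl)phenyl gives a 1.1-fold higher number from compound 2 to compound 3 (0.03 log units; within the scatter), so this change of place does not separate compound 2 and compound 3. Exchanging 4-fluorophenyl for 3-(trifluoromethyl)phenyl on the same sulfur gives a 1.5-fold higher number from compound 1 to compound 3 (0.17 log units; within the scatter), so all three compounds remain within the scatter of the next, whichever of these groups the sulfur carries. Nothing available bears on why these changes leave the numbers so close.

On these data alone, what remains open is whether a different group on that phenyl, such as an amine, a nitrile or a carboxylic acid, would give a step beyond the scatter. As far as these compounds go, it is also open how a sulfone in place of the sulfur would read in this assay.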